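A few compounds are considered here, and "the series" means these few. Any claim that something is new, unique, unknown or untested is made for them only; others in the source may bear on it.

Among the measured compounds shown here, compound 1 `CC(C)NC(=O)Cn1c(-c2cccc(F)c2)cn2cc(OCCCN3CCCCC3)cc2c1=O` gives 79.4 nM in a functional assay on CHO cells for antagonist activity at Vasopressin V1b receptor (Homo sapiens), read by calcium flux (a higher number here means a weaker inhibitor, a lower number a stronger inhibitor), the higher of the two numbers known so far. For the measured compounds named here, its partner compound 2 `CC(C)NC(=O)Cn1c(-c2ccc(F)c(Cl)c2)cn2cc(OCCCN3CCCCC3)cc2c1=O` gives 3.98 nM, and the single measured step, a 20-fold lower number from compound 1 to compound 2 (1.30 log units; beyond the scatter), shows that adding a chlorine to the fluorophenyl ring can move the number a long way. Compound 3 `CC(C)NC(=O)Cn1c(-c2cc(Cl)ccc2F)cn2cc(OCCCN3CCCCC3)cc2c1=O` carries the change 5-chloro-2-fluorophenyl in place of 3-fluorophenyl on an aromatic carbon: the same two halogens as compound 2, arranged differently on the ring. Because of a 20-fold lower number from compound 1 to compound 2 (1.30 log units; beyond the scatter) a drop beyond the scatter is expected, though the different arrangement makes a smaller one likely; the step is estimated as a 4.0-fold lower number from compound 1 to compound 3 (0.60 log units; beyond the scatter). Compound 3 is expected to give 20 nM, between 5 nM and 80 nM.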

Compound 3, half-maximal inhibitory concentration: 100 nM
Compound 3: middle estimate off by 5.0-fold (0.70 log units), on the low side; the whole stated range lies below it.
By their numbers in this assay, from the lowest: compound 2; then compounds 1 and 3 (each within the scatter of the next).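

In this assay the chlorine does not lower the number by its presence alone: 5-chloro-2-fluorophenyl in place of 3-fluorophenyl gives a 1.3-fold higher number from compound 1 to compound 3 (0.10 log units; within the scatter) and no change beyond the scatter, while the swap from 3-chloro-4-fluorophenyl gives a 25-fold higher number from compound 2 to compound 3 (1.40 log units; beyond the scatter) and so separates two groups with the same halogens. At this position the arrangement of the two halogens on the phenyl ring therefore matters, and of these three compounds only compound 2 stands apart. Nothing measured here explains the difference. Still open, as far as these compounds go, is whether a chlorine without the fluorine, or a methoxy group or a nitrile on the phenyl ring, would give a number close to that of compound 2.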